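This account rests on a few compounds, and the source may have more. Where it says the series, first, only, none or still open, it means among the compounds named here.

Measured in a functional assay on A549 cells (Homo sapiens) for antiproliferative activity, read by MTT assay, with a stated time of 72 h; a higher number here means a weaker inhibitor, a lower number a stronger inhibitor:
- compound 1 `CN1CCN(c2ccc(Nc3ncc4nc(Nc5ccccc5)n([C@H]5CCN(C(=O)OC(C)(C)C)C5)c4n3)cc2)CC1`: "not determined" (no result reported)
- compound 2 `CN1CCN(c2ccc(Nc3ncc4nc(Nc5ccc(F)cc5)n([C@@H]5CCN(S(=O)(=O)C6CC6)C5)c4n3)cc2)CC1`: > 10000 nM
- compound 3 `CN1CCN(c2ccc(Nc3ncc4nc(Nc5ccccc5)n([C@H]5CCN(S(C)(=O)=O)C5)c4n3)cc2)CC1`: "not determined" (no result reported)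

The account follows the step to compound 4 `CN1CCN(c2ccc(Nc3ncc4nc(Nc5ccccc5)n([C@@H]5CCN(S(=O)(=O)C6CC6)C5)c4n3)cc2)CC1`, which has yet to be measured. The starting point offers little to go on, since compound 3 stands at "not determined" (no result reported) and so has no single number. Compound 1 is in the same position. Compound 2 gives > 10000 nM, and that is a limit of the assay, not a number.

The structural change is 1-(cyclopropylsulfonyl)pyrrolidin-3-yl in place of 1-(methylsulfonyl)pyrrolidin-3-yl on an aromatic nitrogen. In words, 1-(cyclopropylsulfonyl)pyrrolidin-3-yl takes the place of 1-(methylsulfonyl)pyrrolidin-3-yl on an aromatic nitrogen of a five-membered aromatic ring.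

With no number for compound 3, the step cannot be sized from data, and none beyond the scatter is expected in either direction in this assay. The expectation of weak activity rests on compound 2, whose > 10000 nM is the only limit available. For compound 4 the estimated value is 8000 nM, with an expected range from 2000 nM to 30000 nM.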

Compound 4, half-maximal inhibitory concentration: 2910 nM
Compound 4: middle estimate off by 2.7-fold (0.44 log units), on the high side; measured number inside the range.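

In this assay, among the compounds shown here, compound 4 provides the first single number for a compound carrying 1-(cyclopropylsulfonyl)pyrrolidin-3-yl on the aromatic nitrogen, showing that activity with this group can be measured within the range of the assay. With that group held constant, hydrogen in place of fluoro on an aromatic carbon gives an at least 3.4-fold lower number from compound 2 to compound 4 (0.53 log units; beyond the scatter). The comparison has only a one-sided size, as compound 2 stands at a limit of the assay and not at a number: the limit of > 10000 nM in this assay, at which 1 of the 4 values shown sits.

The step between 1-(methylsulfonyl)pyrrolidin-3-yl and 1-(cyclopropylsulfonyl)pyrrolidin-3-yl still cannot be read, as compound 3 has no reported result. The compounds shown also leave open how an aminoalkylsulfonyl or a longer alkylsulfonyl chain on the pyrrolidine nitrogen would compare in this assay.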